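From 3-fluorobenzyl to 3-bromobenzyl

A few compounds are considered here, and "the series" means these few. Any claim that something is new, unique, unknown or untested is made for them only; others in the source may bear on it.

In a functional assay on B16 cells (Mus musculus) for antiproliferative activity, read by MTT assay, with a stated time of 24 h (a higher number here means a weaker inhibitor, a lower number a stronger inhibitor), compound 1 `COc1cc(OC)c(-c2coc3cc(OCc4ccc(Br)cc4)ccc3c2=O)cc1OC` gives 1180 nM, while compound 2 `COc1cc(OC)c(-c2coc3cc(OCc4cccc(F)c4)ccc3c2=O)cc1OC` stands at the higher number of the pair, 2440 nM. Compound 3 `COc1cc(OC)c(-c2coc3cc(OCc4cccc(Br)c4)ccc3c2=O)cc1OC` carries bromo in place of fluoro on an aromatic carbon, (bromo in place of fluoro on an aromatic carbon). Among the compounds with values here, the only measured step bearing on this is a 2.1-fold higher number from compound 1 to compound 2 (0.32 log units; beyond the scatter), a modest change that alters the halogen and its place together, so it offers partial guidance. The expected change, a 1.5-fold lower number from compound 2 to compound 3 (0.18 log units; within the scatter), is small and toward a lower number, probably within the scatter. For compound 3, the estimate is 1600 nM, with an expected range of 800 nM to 3200 nM.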

Compound 3, half-maximal inhibitory concentration: 4400 nM
Compound 3: the middle estimate sits 2.8-fold (0.44 log units) below what was measured, outside the stated range (above it).
By their numbers in this assay, from the lowest: compound 1; then compounds 2 and 3 (each within the scatter of the next).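

In this assay, bromo in place of fluoro at this meta place gives a 1.8-fold higher number from compound 2 to compound 3 (0.26 log units; within the scatter) and so stays within the scatter, which means that the kind of halogen does not separate this pair. With bromo held fixed, 3-bromophenyl in place of 4-bromophenyl gives a 3.7-fold higher number from compound 1 to compound 3 (0.57 log units; beyond the scatter) and lies beyond the scatter, so the place of the halogen can be read alone here, as the earlier step, which altered both, did not allow. No measured evidence accounts for this difference. Still open, on these data alone, is how an amine on that aromatic carbon, or a longer chain carrying the ring, would read.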